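Swapping the Pyridine Arm in a Kinase Inhibitor Series

The source may hold more compounds than are shown below. What is called first, only, known or untested is meant among the compounds shown, and "the series" means these compounds.

Compound 1, `COc1ccc(OC)c(Sc2ccc3nnc(-c4ccccn4)n3n2)c1`: 1310 nM
Compound 2, `COc1ccc(OC)c(Sc2ccc3nnc(-c4ccncc4)n3n2)c1`: "not determined" (no result reported)

In an assay on HEK293 cells for inhibition of Leucine-rich repeat serine/threonine-protein kinase 2 (Homo sapiens), read by ELISA, with a stated time of 90 min (a higher number here means a weaker inhibitor, a lower number a stronger inhibitor), compound 1 gives 1310 nM. Compound 2 shares the same core, but in this assay compound 2 gives "not determined" (no result reported), so no number stands for it. Compound 3, `COc1cncc(-c2nnc3ccc(Sc4cc(OC)ccc4OC)nn23)c1`, differs from compound 2 in one place: 5-methoxypyridin-3-yl in place of pyridin-4-yl on an aromatic carbon. With no value for compound 2, the step to compound 3 cannot be sized against a measurement; any change beyond the scatter in this assay is uncertain, and a result close to that of compound 1 seems as likely as any. Compound 3 is therefore expected to give about 1200 nM, within 250 nM to 6000 nM.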

Compound 3, half-maximal inhibitory concentration: 440 nM
The estimate for compound 3 lay 2.7-fold (0.44 log units) above the measured number; low and high end bracket the measured number.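

Placing 5-methoxypyridin-3-yl in place of pyridin-2-yl on the shared core brings a 3.0-fold lower number from compound 1 to compound 3 (0.47 log units; beyond the scatter) in this assay and so shows that the reading responds to which pyridine arm sits at this position. The step from compound 2 to compound 3 cannot be read, as compound 2 has no number. Nothing measured here explains the difference.

On these data alone, this swap alters both the methoxy group and the way the pyridine ring is attached, so the share of each remains open. As far as these compounds go, how an amine or a carboxylic acid in place of the methoxy group would read also remains open.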